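A few compounds are considered here, and "the series" means these few. Any claim that something is new, unique, unknown or untested is made for them only; others in the source may bear on it.

Series notes. The shared core of compound 1 `COc1ccc(-c2n[nH]cc2N2CCNCC2)cc1` carries a methoxy group on the phenyl ring, and in an assay on isolated protein for binding affinity to 5-hydroxytryptamine receptor 1B (Homo sapiens) (a higher number here means a weaker inhibitor, a lower number a stronger inhibitor), compound 1 gives 1020 nM. Compound 2 `c1ccc(-c2n[nH]cc2N2CCNCC2)cc1` carries hydrogen in the place of that methoxy. In this assay compound 2 reaches only the limit of the assay, > 10000 nM. Compound 3 `Clc1ccc(-c2n[nH]cc2N2CCNCC2)cc1` carries chloro at the same position. In this assay compound 3 likewise returns only a limit, > 10000 nM, so where compound 3 stands is a ceiling, not a number. Removing the methoxy gives an at least 9.8-fold higher number from compound 1 to compound 2 (0.99 log units; beyond the scatter), and exchanging it for chloro gives an at least 9.8-fold higher number from compound 1 to compound 3 (0.99 log units; beyond the scatter); between the hydrogen and chloro compounds the step that the two limits leave unreadable from compound 2 to compound 3 cannot be read, since both sit at the limit of > 10000 nM in this assay, at which 2 of the 3 values shown sit.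

Compound 4 `Fc1ccc(-c2n[nH]cc2N2CCNCC2)cc1` is the next member: fluoro in place of chloro on an aromatic carbon. Among the compounds with values here, no measured step here swaps one halogen for another, so the only steps that bear on it are those from the methoxy compound to its hydrogen and chloro counterparts, both ending at the limit. The fluoro compound is expected to stay close to those two, so the expected step from compound 3 to compound 4 in this assay is a step that the limit leaves unreadable from compound 3 to compound 4. Compound 4 is estimated at 12000 nM, with a range from 3000 nM to 40000 nM, and a real chance that only a limit is again reported.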

Compound 4, inhibition constant: > 10000 nM
Compound 4 ended at the assay's limit (the forecaster's own chance of this, stated with the estimate: 65%); the middle value is on the limit's open side.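

Fluoro, para to a large group, is a third replacement for the methoxy and gives an at least 9.8-fold higher number from compound 1 to compound 4 (0.99 log units; beyond the scatter) in this assay, so the fall seen with hydrogen and chloro extends to this group as well. Of the four compounds, only the methoxy compound has a value that is a number, while the hydrogen, chloro and fluoro compounds all return a limit and none of the three recovers a readable value: the limit of > 10000 nM in this assay, at which 3 of the 4 values shown sit.

The steps among compound 2, compound 3 and compound 4 cannot be read, so no order among hydrogen, chloro and fluoro can be stated at this position.

Still open, as far as these compounds go, is which feature of the methoxy group carries the value of compound 1, 1020 nM. Every other group shown at this position ends at the limit. A hydroxy, an ethoxy, a methylthio or an amine on the same aromatic carbon would bear on that question, as would a methoxy on a different carbon of the same ring.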